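Adding a Methoxy Group: Cytotoxicity Outlook for Compound 4

The source may report more compounds than this note shows. Statements on the series, on what has been measured and on what is new or still open speak of the compounds shown alone.

Of the compounds shown here, three have been measured in an ADME assay on MT2 cells (Homo sapiens) for cytotoxicity (a lower number here means that less compound is tolerated, a higher number that more compound is tolerated), and a fourth is still to be tested. Compound 1, `CC(C)=CCOc1cc(Nc2ncnc(Cl)n2)ccc1Cl`, gives 45000 nM in this assay. Compound 2, `COc1nc(Cl)nc(Nc2ccc(Cl)c(OCC=C(C)C)c2)n1`, gives 26000 nM. Compound 3, `COc1ccnc(Nc2ccc(Cl)c(OCC=C(C)C)c2)n1`, gives 9000 nM, the lowest of the three numbers, with both other compounds lying beyond the scatter of it. The difference between the core of compound 1 and the core of compound 3 is not broken down here.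

Compound 2 arises from compound 1 by one change, (methoxy in place of hydrogen on an aromatic carbon), and this produced a 1.7-fold lower number from compound 1 to compound 2 (0.24 log units; within the scatter). The compound still to be measured, compound 4, `COc1cc(OC)nc(Nc2ccc(Cl)c(OCC=C(C)C)c2)n1`, arises from compound 3 by the same kind of change, (methoxy in place of hydrogen on an aromatic carbon). The surroundings differ, however: in compound 2 the new group sits between two ring nitrogen atoms and meta to a chloro group on a six-membered aromatic ring with 3 nitrogen, whereas in compound 4 it sits next to the ring nitrogen and meta to a methoxy group on a six-membered aromatic ring with 2 nitrogen.

Going by the values given here, because the only measured example of this kind of change, a 1.7-fold lower number from compound 1 to compound 2 (0.24 log units; within the scatter), stayed within the scatter, the step from compound 3 to compound 4 in this assay is expected to be small as well, about a 1.3-fold lower number from compound 3 to compound 4 (0.11 log units; within the scatter). Compound 4 is therefore estimated at 7000 nM in this assay, with a likely range from 3000 nM to 16000 nM.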

Compound 4, half-maximal cytotoxic concentration: 28000 nM
The estimate for compound 4 lay 4.0-fold (0.60 log units) below the measured number; measured number outside the range, above it.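

In this assay, methoxy in place of hydrogen on an aromatic carbon gave a 3.1-fold higher number from compound 3 to compound 4 (0.49 log units; beyond the scatter), a step beyond the scatter that runs in the opposite direction to the earlier step, which stayed within the scatter. This shows that the result of the change on one core did not carry over to the other in this series, so the earlier step gave no safe guide to either its size or its direction here. Going by these compounds alone, it does not show which difference between the two cores or the surroundings of the new group separates the results, and with only two pairs it gives no rule for any further core, but the two steps do differ: the same change on two cores in this assay, a 1.7-fold lower number (0.24 log units; within the scatter) from compound 1 to compound 2 and a 3.1-fold higher number (0.49 log units; beyond the scatter) from compound 3 to compound 4, 5.4-fold (0.73 log units) apart, beyond the scatter of two such steps.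

The compounds shown leave open whether the higher number on this core belongs to methoxy in particular or would also appear with another group in the same place, such as an amine, an ethoxy group or a longer ether chain. They also leave open whether a second pair on a six-membered aromatic ring with 2 nitrogen would repeat the step seen here or fall closer to the earlier one.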